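Replacing Amino with Nitro on the Aromatic Ring

A few compounds are considered here, and "the series" means these few. Any claim that something is new, unique, unknown or untested is made for them only; others in the source may bear on it.

Compound 1 `COC(=O)C1=C(C)N=C(C)/C(=C(\O)OC)C1c1cccc(N)c1` gives 2000 nM in a functional assay (muscle tissue) with Cavia porcellus as the target (a higher number here means that more compound is needed for the effect, a lower number that less compound is needed), the highest of the three numbers in hand. Compound 2 `COC(=O)C1=C(C)N=C(C)/C(=C(\O)OC)C1c1cccc(Cl)c1Cl` gives 19.1 nM in this assay, and compound 3 `COC(=O)C1=C(C)N=C(C)/C(=C(\O)OC)C1c1cc(C)ccc1C` gives 100 nM. Each step away from compound 1 changes only the group on the six-membered aromatic ring of carbon only, and each lowers the number greatly: a 100-fold lower number from compound 1 to compound 2 (2.02 log units; beyond the scatter) and a 20-fold lower number from compound 1 to compound 3 (1.30 log units; beyond the scatter). Compound 4 `COC(=O)C1=C(C)N=C(C)/C(=C(\O)OC)C1c1cccc([N+](=O)[O-])c1` differs from compound 1 in a single place: nitro in place of amino on an aromatic carbon. Among the measured compounds shown here, no measured step puts nitro in place of amino, so the two steps from compound 1 are the only guide; they show that changing the group on this aromatic ring of compound 1 can move the number far, and in both cases downward. A step in the same direction, though smaller than the largest seen, is therefore expected, a 33-fold lower number from compound 1 to compound 4 (1.52 log units; beyond the scatter). Compound 4 is expected to give about 60 nM in this assay, with a range from 6 nM to 600 nM.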

Compound 4, half-maximal effective concentration: 3.98 nM
Estimate against measurement, compound 4: 15-fold (1.18 log units) above; the measured number lies below the stated range.
By their numbers in this assay, from the lowest: compound 4; then compound 2; then compound 3; then compound 1.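

Swapping only the group on one aromatic carbon, meta to a large group, gives a 500-fold lower number from compound 1 to compound 4 (2.70 log units; beyond the scatter) in this assay, so a single change at this place can account for a very large shift in the number. The earlier steps shown here each replaced the amino group with a different pair of ring groups, whereas this one leaves the rest of compound 1 untouched and puts compound 4 ahead of compound 2 in the order from the lowest number. No measurement in hand explains why nitro and amino differ so widely here.

The compounds shown leave open how a nitrile or a trifluoromethyl group on this same carbon would compare with nitro. They also leave open what nitro would give on another carbon of the ring, and what a ring carrying only hydrogen would give.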